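The source may hold more compounds than are shown below. What is called first, only, known or untested is meant among the compounds shown, and "the series" means these compounds.

In a functional assay on HCT-116 cells (Homo sapiens) for cytotoxicity, read by MTT assay, with a stated time of 48 h (on this read-out higher numbers stand for weaker inhibition and lower numbers for stronger inhibition), the measured values are these:

compound 1 `COc1cc(/C=C/c2ccc(OCCCC(=O)NO)cc2)cc(OC)c1` - 5200 nM
compound 2 `COc1cc(/C=C/c2ccc(OCCCCC(=O)NO)cc2)cc(OC)c1` - 3350 nM

Going by the values given here, compound 1 stands within the usual scatter of compound 2, the only other compound measured, so the two numbers cannot be told apart. Compound 3 `COc1cc(/C=C/c2ccc(OCCCCCC(=O)NO)cc2)cc(OC)c1` has yet to be measured and differs from compound 1 by a single change (2-(hydroxycarbamoyl)ethyl in place of hydroxycarbamoyl on a saturated chain carbon, three bonds along the chain from an oxygen on an aromatic ring), namely 2-(hydroxycarbamoyl)ethyl in place of hydroxycarbamoyl on a saturated chain carbon, three bonds along the chain from an oxygen on an aromatic ring. Among the compounds with values here, the one measured step that bears on this is (hydroxycarbamoyl)methyl in place of hydroxycarbamoyl at that same carbon (a 1.6-fold lower number from compound 1 to compound 2 (0.19 log units; within the scatter)). A single small step establishes no trend. A step of similar size is therefore expected in this assay for the further change, leaning towards a lower number, with nothing foreseen beyond the scatter. The expected shift (a 1.7-fold lower number from compound 1 to compound 3 (0.24 log units; within the scatter)) remains modest. Compound 3 is estimated at 3000 nM with an expected range from 1200 nM to 6500 nM in this read-out.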

Compound 3, half-maximal inhibitory concentration: 4100 nM
Beside the measured number, compound 3's estimate is 1.4-fold (0.14 log units) below it, and the stated range covers the measured number.
By their numbers in this assay, from the lowest: compounds 2, 3 and 1 (each within the scatter of the next).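

The position now has two changes read against the same starting point, and in this assay neither (hydroxycarbamoyl)methyl nor 2-(hydroxycarbamoyl)ethyl in place of hydroxycarbamoyl, on a saturated chain carbon, three bonds along the chain from an oxygen on an aromatic ring, leaves the scatter: the new change gives a 1.3-fold lower number from compound 1 to compound 3 (0.10 log units; within the scatter) and stays within it. Going by these compounds alone, the same difference read one bond further out, (hydroxycarbamoyl)methyl in place of hydroxycarbamoyl, four bonds along the chain from that oxygen, gives a 1.2-fold higher number from compound 2 to compound 3 (0.09 log units; within the scatter) and also stays within the scatter, so the single step seen earlier does not grow into a trend, and no dependence on chain length can be read across these three compounds. Nothing on hand speaks to why these chains are not told apart here.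

What the compounds shown leave open is whether a longer chain at this carbon would give a number beyond the scatter of these three. They also leave open whether a carboxylic acid or a primary amide in place of the hydroxycarbamoyl end would shift the number in this assay at all.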